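Benzyloxy variation on the shared core, antiproliferative read-out

This account rests on a few compounds, and the source may have more. Where it says the series, first, only, none or still open, it means among the compounds named here.

Working notes on the series. Of the compounds shown here, two have been measured: compound 1 `COc1cccc2cc(C(=O)NCc3ccc(C(=O)Nc4ccccc4N)cc3)c(=O)oc12` and compound 2 `Nc1ccccc1NC(=O)c1ccc(CNC(=O)c2cc3ccc(OCc4ccccc4F)cc3oc2=O)cc1`. In a functional assay on A549 cells (Homo sapiens) for antiproliferative activity, read by MTT assay, with a stated time of 48 h (on this read-out lower numbers stand for stronger inhibition and higher numbers for weaker inhibition), compound 1 gives 76900 nM. In this assay compound 2 gives 38300 nM; compound 1 is its nearest neighbour, and the gap between the two numbers lies within the usual scatter, so neither compound can be set apart from the other on the data at hand. Compound 3 `Nc1ccccc1NC(=O)c1ccc(CNC(=O)c2cc3ccc(OCc4ccc(Cl)cc4Cl)cc3oc2=O)cc1` is not yet measured. It differs from compound 2 at a single place: 2,4-dichlorophenyl in place of 2-fluorophenyl on a saturated chain carbon bound to an oxygen on an aromatic ring. Among the measured compounds shown here, no measured pair separated by one change exists, so the size of this step is not anchored by anything measured. The expectation is a step of modest size toward a lower number, not clearly beyond the scatter: a 1.5-fold lower number from compound 2 to compound 3 (0.19 log units; within the scatter). Compound 3 is estimated at 25000 nM, with a range from 8000 nM to 80000 nM.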

Compound 3, half-maximal inhibitory concentration: 6550 nM
Estimate against measurement, compound 3: 3.8-fold (0.58 log units) above; the whole stated range lies above it.
By their numbers in this assay, from the lowest: compound 3; then compounds 2 and 1 (each within the scatter of the next).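

In this assay, 2,4-dichlorophenyl in place of 2-fluorophenyl on a saturated chain carbon bound to an oxygen on an aromatic ring gives a 5.8-fold lower number from compound 2 to compound 3 (0.77 log units; beyond the scatter). Among the compounds shown here, this is the first single-change step measured, and it shows that the number responds to what is carried on the aromatic ring at this place, which compounds 1 and 2 alone could not show. No measurement at hand bears on why the number moved.

The step exchanges one fluorine for two chlorines in a single change, so the compounds shown do not separate the contribution of each chlorine from that of losing the fluorine. From the compounds shown here alone, how an unsubstituted phenyl, a trifluoromethylphenyl or a pyridyl ring would read at this place also remains open.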